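This account rests on a few compounds, and the source may have more. Where it says the series, first, only, none or still open, it means among the compounds named here.

Three compounds share one core and differ only in the group attached to the amine nitrogen of the side chain. Compound 1 `OCCNCc1nc2c(OCC3CCCCC3)cccc2[nH]1` gives 20000 nM in an assay on cells for inhibition of interleukin-5 receptor subunit alpha (Mus musculus), read by WST assay, with a stated time of 48 h, in the presence of a further agent that is not named here; on this read-out higher numbers stand for weaker inhibition and lower numbers for stronger inhibition. Compound 2 `OCCCNCc1nc2c(OCC3CCCCC3)cccc2[nH]1` gives 28500 nM, and the step of a 1.4-fold higher number from compound 1 to compound 2 (0.15 log units; within the scatter) stays inside the usual scatter, so the two numbers cannot be told apart. For compound 3 `c1ccc(CNCc2nc3c(OCC4CCCCC4)cccc3[nH]2)cc1` the assay reports only a limit, > 30000 nM, and not a number; this is the limit of > 30000 nM in this assay, at which 1 of the 3 values shown sits.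

The step of interest leads from compound 2 to compound 4 `COc1ccc(CNCc2nc3c(OCC4CCCCC4)cccc3[nH]2)cc1`, where the change is 4-methoxyphenyl in place of 2-hydroxyethyl on a saturated chain carbon bound to an amine nitrogen. The closest measured step is an at least 1.0-fold higher number from compound 2 to compound 3 (0.02 log units; that floor lies within the scatter), in which a phenyl likewise took the place of the 2-hydroxyethyl, and an at least 1.5-fold higher number from compound 1 to compound 3 (0.17 log units; that floor lies within the scatter) points the same way. Both end at a limit, so the expected outcome for compound 4 is a number at or beyond that floor, with a step of a 1.4-fold higher number from compound 2 to compound 4 (0.15 log units; within the scatter) estimated from compound 2. For compound 4 the estimated result is 40000 nM, with a range expected from 15000 nM to 100000 nM.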

Compound 4, half-maximal inhibitory concentration: > 30000 nM
Compound 4 ended at the assay's limit; the forecaster's own chance of this, stated with the estimate: 65%; the middle value is on the limit's open side.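

Compound 4 shows that a methoxy on the aromatic ring does not bring the aromatic compounds back into the measurable range of this assay, as it too gives a limit and not a number: the limit of > 30000 nM in this assay, at which 2 of the 4 values shown sit.

Measured against the two hydroxy chains, the result reads as an at least 1.0-fold higher number from compound 2 to compound 4 (0.02 log units; that floor lies within the scatter) and as an at least 1.5-fold higher number from compound 1 to compound 4 (0.17 log units; that floor lies within the scatter), and both figures are only floors, so the true gaps may be larger. The step between compound 3 and compound 4 cannot be read, so any effect of the methoxy itself stays hidden.

As far as these compounds go, it remains open whether a group such as an amine or a carboxylic acid in place of the 2-hydroxyethyl would give clearly stronger inhibition. From the compounds shown here alone, it is equally open whether a longer chain ending in hydroxy would do so.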